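The source may report more compounds than this note shows. Statements on the series, on what has been measured and on what is new or still open speak of the compounds shown alone.

Measured compounds in an assay for inhibition of Polyunsaturated fatty acid 5-lipoxygenase (Homo sapiens), read by spectrophotometry, tested at 10 uM, in the presence of a further agent that is not named here; a higher number here means more inhibition at the concentration tested (going by the name of the read-out), a lower number less inhibition:
compound 1 `Cc1nc(NC(=O)c2ccccc2)sc1C(=O)/C=C/c1ccc(Cl)cc1` — 63.7%
compound 2 `COc1ccc(C(=O)Nc2nc(C)c(C(=O)/C=C/c3ccc(F)cc3)s2)cc1` — 88.2%
compound 3 `Cc1nc(NC(=O)c2ccc([N+](=O)[O-])cc2)sc1C(=O)/C=C/c1ccc(Cl)cc1` — 48.8%

Compound 1 stands second highest of the three numbers in this assay. Its nearest neighbour is compound 3, reached by nitro in place of hydrogen on an aromatic carbon, with a drop of a number 14.9 percentage points lower from compound 1 to compound 3 (beyond the scatter), a modest step but beyond the scatter. For the measured compounds named here, compound 2 gives the highest number of the three; it differs from compound 1 in two places, so no single step between them is available and only the two values themselves can be compared.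

Compound 4 `COc1ccc(/C=C/C(=O)c2sc(NC(=O)c3ccccc3)nc2C)cc1` is not yet measured. It differs from compound 1 by methoxy in place of chloro on an aromatic carbon. Taken one bond further out, the change reads 4-chlorophenyl to 4-methoxyphenyl.

Going by the values given here, no measured step matches this change. Among the compounds with values here, the one step that is known concerns a different group on a different ring, so it does not bear on it directly. Compound 2 carries a methoxy, but on the other aromatic ring and together with a second change. With nothing to anchor direction, a step within the scatter is expected, in either direction: a number 2.3 percentage points higher from compound 1 to compound 4 (within the scatter). For compound 4 the estimate in this assay is 66%, with a range from 45% to 85%.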

Compound 4, a percentage reported as inhibition, at one concentration (the size of the read-out at that concentration, not a potency): 58.8%
For compound 4 the middle estimate is 7.2 percentage points above the measured one, within the range that was stated.
By their numbers in this assay, from the lowest: compounds 3, 4 and 1 (each within the scatter of the next, the first and the last beyond it); then compound 2.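

For the compounds shown here, the step of a number 4.9 percentage points lower from compound 1 to compound 4 (within the scatter) is the first reading at this place, on an aromatic carbon of a six-membered aromatic ring of carbon only, para to a large group, and it comes from this assay. The earlier single step concerned nitro on the other aromatic ring, so the exchange of 4-chlorophenyl for 4-methoxyphenyl had no reading of its own until now. In this pair, methoxy, with 2 heavy atoms and 1 hydrogen-bond acceptor, and chloro, with 1 heavy atom and no hydrogen-bond acceptor, cannot be told apart by this read-out at the single concentration tested. No evidence bearing on this result is available.

On these data alone, whether an amine, a carboxylic acid or a longer chain at this place would move the number beyond the scatter stays open, as one pair of groups says little about the place as a whole. The separate contributions of the two changes between compound 1 and compound 2 also cannot be read, and the same holds for the other pairs that differ in more than one place.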